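Heteroaryl swaps on the piperazine nitrogen of a quinazoline amine

A few compounds are considered here, and "the series" means these few. Any claim that something is new, unique, unknown or untested is made for them only; others in the source may bear on it.

Measured compounds:
compound 1 `COc1cc2nc(N3CCN(c4cccnn4)CC3)nc(N)c2cc1OC`, 0.4 nM
compound 2 `COc1cc2nc(N3CCN(c4nccc(N(C)C)n4)CC3)nc(N)c2cc1OC`, 0.27 nM

Both measured compounds share one core and differ only in the heteroaryl group on the amine nitrogen in a ring. In an assay on brain for binding affinity to Adrenergic receptor alpha-1 (Rattus norvegicus) (on this read-out higher numbers stand for weaker inhibition and lower numbers for stronger inhibition), compound 1 gives 0.4 nM, and compound 2 gives 0.27 nM. The two values lie within the scatter of each other: a 1.5-fold lower number from compound 1 to compound 2 (0.17 log units; within the scatter). Compound 2 thus stands with compound 1, and nothing separates them on this read-out.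

Compound 3 `COc1nc(OC)nc(N2CCN(c3nc(N)c4cc(OC)c(OC)cc4n3)CC2)n1` is not yet measured. Its difference from compound 2 is 4,6-dimethoxy-1,3,5-triazin-2-yl in place of 4-(dimethylamino)pyrimidin-2-yl on an amine nitrogen in a ring. For the measured compounds named here, the only measured step that bears on this change is the heteroaryl exchange at the same amine nitrogen in a ring, from compound 1 to compound 2, which stayed within the scatter. On that basis no step beyond the scatter is expected from compound 2 to compound 3 in this assay; the estimated step is a 1.5-fold higher number from compound 2 to compound 3 (0.17 log units; within the scatter). Compound 3 is therefore expected to give about 0.4 nM, with a range from 0.1 nM to 1.5 nM.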

Compound 3, inhibition constant: 0.08 nM
Compound 3: the middle estimate sits 5.0-fold (0.70 log units) above what was measured; the whole stated range lies above it.
By their numbers in this assay, from the lowest: compound 3; then compounds 2 and 1 (each within the scatter of the next).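

The heteroaryl group on the amine nitrogen in a ring is not interchangeable in this assay: 4,6-dimethoxy-1,3,5-triazin-2-yl gives a 3.4-fold lower number from compound 2 to compound 3 (0.53 log units; beyond the scatter) and also a 5.0-fold lower number from compound 1 to compound 3 (0.70 log units; beyond the scatter) when it replaces pyridazin-3-yl. For the compounds shown here, the exchange between the earlier compounds had stayed within the scatter, so these are the first steps to show that this place can change the read-out, and compound 3 now has the lowest number of the three. The entering group differs from 4-(dimethylamino)pyrimidin-2-yl at once in its ring, with three hetero atoms instead of two, and in its substituents, with methoxy groups in place of dimethylamino, and no measurement on hand ties the step to any property of the group or gives a reason for it.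

The compounds shown leave open whether the step follows the triazine ring or the methoxy groups, a separation that 4,6-bis(dimethylamino)-1,3,5-triazin-2-yl and 4,6-dimethoxypyrimidin-2-yl could each address. They also leave open how far the trend extends to longer alkoxy groups such as ethoxy at the same place.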